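The source may hold more compounds than are shown below. What is called first, only, known or untested is meant among the compounds shown, and "the series" means these compounds.

Compound 3 `CC(C)c1ccc(-c2sc(N)c(C(=O)c3ccc(Cl)cc3)c2CC(C)(C)C)cc1` is one of three compounds built on a shared core and measured in an assay on CHO cells for displacement of a labelled ligand from adenosine receptor A3 (Homo sapiens), read by scintillation counting, tested at 10 uM; on this read-out higher numbers stand for more inhibition at the one concentration tested (going by the name of the read-out) and lower numbers for less inhibition; in this assay compound 3 gives 1%. Compound 1 `CC(C)(C)Cc1c(-c2cccnc2)sc(N)c1C(=O)c1ccc(Cl)cc1` gives 1% in this assay, and compound 2 `CC(C)(C)Cc1c(-c2ccc(F)cc2)sc(N)c1C(=O)c1ccc(Cl)cc1` gives 9%. Compound 3 thus stands level with compound 1 at the digits shown, the step being no change at the digits printed from compound 1 to compound 3 (within the scatter), while to compound 2 the step is a number 8 percentage points lower from compound 2 to compound 3 (within the scatter); all three numbers lie within the scatter of one another.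

Compound 4 `CC(C)(C)Cc1c(-c2cn[nH]c2)sc(N)c1C(=O)c1ccc(Cl)cc1` differs from compound 3 by 1H-pyrazol-4-yl in place of 4-isopropylphenyl on an aromatic carbon. The three measured steps all alter the group on this same aromatic carbon: a number 8 percentage points higher from compound 1 to compound 2 (within the scatter), no change at the digits printed from compound 1 to compound 3 (within the scatter) and a number 8 percentage points lower from compound 2 to compound 3 (within the scatter), none beyond the scatter. Within the data shown here, no measured step puts a five-membered ring with two hetero atoms at this position, so the expectation rests on the three numbers staying low whatever group sits there. Compound 4 is therefore expected to show no change beyond the scatter, a step of a number 2 percentage points higher from compound 3 to compound 4 (within the scatter). Compound 4 is estimated at 3%, in a range from 0% to 12%.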

Compound 4, a percentage reported as inhibition, at one concentration (the size of the read-out at that concentration, not a potency): 1%
Beside the measured number, compound 4's estimate is 2 percentage points above it; the range from low to high includes it.
By their numbers in this assay, from the lowest: compounds 1, 3, 4 and 2 (each within the scatter of the next).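

In this assay the swap to 1H-pyrazol-4-yl brings the first five-membered ring with 2 hetero atoms to this carbon next to the ring sulfur, and with it a hydrogen-bond donor, yet each comparison stays within the scatter (no change at the digits printed from compound 3 to compound 4 (within the scatter); no change at the digits printed from compound 1 to compound 4 (within the scatter); a number 8 percentage points lower from compound 2 to compound 4 (within the scatter)). The flat read-out at this position therefore now extends beyond six-membered rings to a smaller ring that carries fewer heavy atoms than 4-isopropylphenyl. No supporting data bear on why these numbers stay together.

The compounds shown leave open whether a non-aromatic group on this carbon, such as a carboxylic acid or a primary amine on a longer chain, would move the number beyond the scatter. They also leave open whether replacing the neopentyl group with a cyclohexyl ring would do so.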